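Methoxy for methylsulfanyl at the assay limit

The source may report more compounds than this note shows. Statements on the series, on what has been measured and on what is new or still open speak of the compounds shown alone.

Measured in a functional assay on HUVEC cells (Homo sapiens) for antiproliferative activity, read by MTT assay, with a stated time of 24 h; on this read-out lower numbers stand for stronger inhibition and higher numbers for weaker inhibition:
compound 1 `C=CCc1cc(-c2cccc([N+](=O)[O-])c2)ccc1O`: > 100000 nM
compound 2 `C=CCc1cc(-c2cccc(SC)c2)ccc1O`: > 100000 nM

Compound 1 gives > 100000 nM as a limit of the assay. Compound 2 gives > 100000 nM, likewise a limit and not a number, so it has no readable place in the series. Compound 3 `C=CCc1cc(-c2cccc(OC)c2)ccc1O` carries methoxy in place of methylsulfanyl on an aromatic carbon, meta to a large group (methoxy in place of methylsulfanyl on an aromatic carbon). Going by the values given here, the only measured step, a step that the two limits leave unreadable from compound 1 to compound 2, has no readable size and gives no direction. The remaining guide is the limit of > 100000 nM in this assay, at which 2 of the 2 values shown sit. No change beyond the scatter is therefore expected in this assay, and the expected step of a number no higher from compound 2 to compound 3 (the limit leaves the size open) is read in that light. Compound 3 is estimated at 100000 nM, with an expected range of 30000 nM to 200000 nM, and a report as a limit alone is the likeliest outcome.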

Compound 3, half-maximal inhibitory concentration: > 100000 nM
Compound 3: a limit, no number (the forecaster's own chance of this, stated with the estimate: 80%); the middle value lies on the limit itself.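

In this assay compound 3 gives > 100000 nM, a limit and not a number. No step among compound 1, compound 2 and compound 3 can be read: the limit of > 100000 nM in this assay, at which 3 of the 3 values shown sit.

The compounds shown leave open whether nitro, methylsulfanyl and methoxy differ at all in this assay.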